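The source may hold more compounds than are shown below. What is called first, only, known or untested is meant among the compounds shown, and "the series" means these compounds.

Measured compounds:
compound 1, `COc1ccc(-n2cc(NC(=O)c3cccc(NS(=O)(=O)c4ccccc4)c3)cn2)cc1` — 42200 nM
compound 2, `COc1cccc(-n2cc(NC(=O)c3cccc(NS(=O)(=O)c4ccccc4)c3)cn2)c1` — 26200 nM
compound 3, `COc1ccc(-n2cc(NC(=O)c3cccc(NS(=O)(=O)c4ccc(Cl)cc4)c3)cn2)cc1` — 19700 nM

In a functional assay on HeLa cells (Homo sapiens) for inhibition, read by MTT assay, with a stated time of 48 h (on this read-out lower numbers stand for stronger inhibition and higher numbers for weaker inhibition), compound 3 gives the lowest of the three numbers, though compound 2 is within the scatter of it; only a 2.1-fold lower number from compound 1 to compound 3 (0.33 log units; beyond the scatter) lies beyond the scatter. Compound 4, `COc1cccc(-n2cc(NC(=O)c3cccc(NS(=O)(=O)c4ccc(Cl)cc4)c3)cn2)c1`, has not been measured. It differs from compound 3 by 3-methoxyphenyl in place of 4-methoxyphenyl on an aromatic nitrogen. The same change, (3-methoxyphenyl in place of 4-methoxyphenyl on an aromatic nitrogen), was already made on the core of compound 1, where it gave a 1.6-fold lower number from compound 1 to compound 2 (0.21 log units; within the scatter). The cores of compound 1 and compound 3 differ by chloro in place of hydrogen on an aromatic carbon. Since the place of the change is the same in both pairs, a step of comparable size is expected, a 1.5-fold lower number from compound 3 to compound 4 (0.18 log units; within the scatter), resting on the step from compound 1 to compound 2. Compound 4 is therefore estimated at 13000 nM, between 6500 nM and 28000 nM.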

Compound 4, half-maximal inhibitory concentration: 25000 nM
Estimate against measurement, compound 4: 1.9-fold (0.28 log units) below; measured number inside the range.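

In this assay, 3-methoxyphenyl in place of 4-methoxyphenyl on the chloro-bearing core gave a 1.3-fold higher number from compound 3 to compound 4 (0.10 log units; within the scatter), and this step does not differ from the one on the core of compound 1: the same change on two cores in this assay, a 1.6-fold lower number (0.21 log units; within the scatter) from compound 1 to compound 2 and a 1.3-fold higher number (0.10 log units; within the scatter) from compound 3 to compound 4, 2.0-fold (0.31 log units) apart, within the scatter of two such steps. Chloro in place of hydrogen gave a 1.0-fold lower number from compound 2 to compound 4 (0.02 log units; within the scatter), and this step likewise does not differ from the one seen earlier: the same change on two cores in this assay, a 2.1-fold lower number (0.33 log units; beyond the scatter) from compound 1 to compound 3 and a 1.0-fold lower number (0.02 log units; within the scatter) from compound 2 to compound 4, 2.0-fold (0.31 log units) apart, within the scatter of two such steps. Across these four compounds, neither change is shown to depend on the core, but this does not show that the two changes are independent in general, as only two cores are compared and the steps are small.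

On these data alone, it remains open whether the same would hold for larger steps. Bromo or methyl in place of chloro, or an amine or a carboxylic acid in place of methoxy, might test this.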